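Thiophen-3-yl in place of cyclohex-1-en-1-yl

A few compounds are considered here, and "the series" means these few. Any claim that something is new, unique, unknown or untested is made for them only; others in the source may bear on it.

In an ADME assay (liver) for metabolic stability, with Liver microsome (Rattus norvegicus) as the target, using microsomes (on this read-out higher numbers stand for fast clearance and lower numbers for slow clearance), compound 3 `O=C(O)c1csc(-n2nc(C3=CCCCC3)c3ccccc32)n1` gives 490 mL/min/kg. That number lies within the scatter of compound 1 `COc1ccc(-c2nn(-c3nc(C(=O)O)cs3)c3ccccc23)cc1` at 618 mL/min/kg and stands higher than compound 2 `O=C(O)c1csc(-n2nc(C3=CCCC3)c3ccccc32)n1` at 196 mL/min/kg. Compound 4 `O=C(O)c1csc(-n2nc(-c3ccsc3)c3ccccc32)n1` differs from compound 3 by thiophen-3-yl in place of cyclohex-1-en-1-yl on an aromatic carbon. Within the data shown here, no measured step involves thiophen-3-yl directly. The nearest evidence is a 1.3-fold lower number from compound 1 to compound 3 (0.10 log units; within the scatter), within the scatter, set against the modest 3.2-fold lower number from compound 1 to compound 2 (0.50 log units; beyond the scatter) and a 2.5-fold higher number from compound 2 to compound 3 (0.40 log units; beyond the scatter). Thiophen-3-yl is aromatic like 4-methoxyphenyl and five-membered like cyclopent-1-en-1-yl, so these steps point in opposite directions. No change beyond the scatter is therefore expected in this assay. The expected step is a 1.2-fold lower number from compound 3 to compound 4 (0.07 log units; within the scatter). Compound 4 is estimated at 420 mL/min/kg, with an expected range from 180 mL/min/kg to 900 mL/min/kg.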

Compound 4, clearance: 190 mL/min/kg
For compound 4 the middle estimate is 2.2-fold (0.34 log units) above the measured one; the measured number falls inside the stated range.
By their numbers in this assay, from the lowest: compounds 4 and 2 (each within the scatter of the next); then compounds 3 and 1 (each within the scatter of the next).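

Thiophen-3-yl at this position in this assay separates from cyclohex-1-en-1-yl (a 2.6-fold lower number from compound 3 to compound 4 (0.41 log units; beyond the scatter)) and from 4-methoxyphenyl (a 3.3-fold lower number from compound 1 to compound 4 (0.51 log units; beyond the scatter)), but not from cyclopent-1-en-1-yl (a 1.0-fold lower number from compound 2 to compound 4 (0.01 log units; within the scatter)). Across compounds 1 to 4, the two five-membered rings therefore give the low numbers and the two six-membered rings the high numbers, whether aromatic or not, and no compound goes against this. Nothing shown accounts for the split.

Open, going by these compounds, is whether the split holds for a saturated ring such as cyclopentyl or cyclohexyl. Also open, on these data alone, is the effect of an amine on the five-membered ring.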